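Adding Chloro to the Benzyl Arm of Compound 3

The source may report more compounds than this note shows. Statements on the series, on what has been measured and on what is new or still open speak of the compounds shown alone.

Three compounds have been measured:
Compound 1, `CC1=C(C(=O)Nc2ccc([N+](=O)[O-])cc2)C(c2ccc(Br)cc2)N=C(SCc2ccccc2)N1`, gives 2.1%.
Compound 2, `CC1=C(C(=O)Nc2ccc([N+](=O)[O-])cc2)C(c2ccc(Br)cc2)N=C(SCc2cccc(Cl)c2)N1`, gives 2.1%.
Compound 3, `CC1=C(C(=O)Nc2ccc([N+](=O)[O-])cc2)C(c2cccc([N+](=O)[O-])c2)N=C(SCc2ccccc2)N1`, gives 2.6%.

All three share one core and were tested in a functional assay on the whole organism (artery, strain albino) with Rattus norvegicus as the target, with a stated time of 15 min, at a dose of 10 mg/kg by the oral route; a lower number here means less inhibition, a higher number more inhibition at the dose given (going by the name of the read-out). Compound 3 carries the highest of the three numbers, yet the gap to compound 1, a number 0.5 percentage points higher from compound 1 to compound 3 (within the scatter), and the gap to compound 2 both lie within the scatter of repeated measurements, so the three cannot be placed in any order; all of them sit near the bottom of the scale.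

Compound 4, `CC1=C(C(=O)Nc2ccc([N+](=O)[O-])cc2)C(c2cccc([N+](=O)[O-])c2)N=C(SCc2cccc(Cl)c2)N1`, has not yet been measured. It differs from compound 3 in one place: chloro in place of hydrogen on an aromatic carbon. Exactly this change has already been made once within the set, from compound 1 to compound 2, where the benzyl became a 3-chlorobenzyl and the result was no change at the digits printed from compound 1 to compound 2 (within the scatter). Within the data shown here, that single precedent is the only guide, and it points to no movement. The step from compound 3 to compound 4 is therefore expected to be no change at the digits printed from compound 3 to compound 4 (within the scatter), nothing beyond the scatter. In this assay compound 4 is estimated to give 2.6%, with a range from 0% to 9%.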

Compound 4, a percentage reported as inhibition, in the whole organism at one dose (the size of the read-out at that dose, not a potency): 2.6%
Estimate against measurement, compound 4: no gap at the digits printed; measured number inside the range.
By their numbers in this assay, from the lowest: compounds 1, 2, 3 and 4 (each within the scatter of the next).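

The new step reads no change at the digits printed from compound 3 to compound 4 (within the scatter), so the exchange of hydrogen for chloro on the benzyl arm can now be compared on two cores in this assay, one carrying 4-bromophenyl and the other 3-nitrophenyl: the same change on two cores in this assay, no change at the digits printed (within the scatter) from compound 1 to compound 2 and no change at the digits printed (within the scatter) from compound 3 to compound 4, 0 percentage points apart, within the scatter of two such steps. The exchange of 4-bromophenyl for 3-nitrophenyl can also be read a second time, now with 3-chlorobenzyl in place of benzyl, and it gives a number 0.5 percentage points higher from compound 2 to compound 4 (within the scatter): the same change on two cores in this assay, a number 0.5 percentage points higher (within the scatter) from compound 1 to compound 3 and a number 0.5 percentage points higher (within the scatter) from compound 2 to compound 4, 0 percentage points apart, within the scatter of two such steps. Together, the two pairs show that neither change, in either setting, moves the read-out beyond the scatter at this single dose, so the two changes show no sign of depending on each other within these four compounds.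

All four numbers lie near the bottom of the scale, and a single dose there cannot show whether the compounds differ in potency. On these data alone, it also stays open whether an amine or a carboxylic acid in place of the chloro, or a longer chain in place of the benzyl, would bring the number clear of the scatter.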